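The compounds below may be only part of what the source reports. "The series", "measured", "known", "first", "only" and "open" are said of these compounds alone.

In a functional assay on NCI-H460 cells (Homo sapiens) for positive allosteric modulation, read by MTT assay, with stated times of 2 h and 72 h, tested at 3 uM (a higher number here means a weaker inhibitor, a lower number a stronger inhibitor), compound 1 (`COc1ccc(C(=O)Nc2ccccc2-c2nnn(-c3ccc(OC)cc3)n2)cc1`) gives 156 nM and compound 2 (`COc1cccc(-n2nnc(-c3ccccc3NC(=O)c3ccc(N)cc3)n2)c1`) gives 212 nM. Compound 3 (`COc1cccc(-n2nnc(-c3ccccc3NC(=O)c3ccc(NC(C)=O)cc3)n2)c1`) gives 554 nM, the highest of the three numbers. Compound 4 (`COc1cccc(-n2nnc(-c3ccccc3NC(=O)c3ccc(NC(=O)CBr)cc3)n2)c1`) differs from compound 3 by one change: bromo in place of hydrogen on a saturated chain carbon bound to a carbonyl carbon. Among the compounds with values here, one measured step bears on this, a 2.6-fold higher number from compound 2 to compound 3 (0.42 log units; beyond the scatter), a modest step that placed acetyl in place of hydrogen on a nitrogen on an aromatic ring. Within the data shown here, no measured step tests bromo itself. No shift beyond the scatter is therefore expected in this assay. The expected change is a 1.4-fold lower number from compound 3 to compound 4 (0.14 log units; within the scatter). For compound 4 the estimated value is 400 nM, with an expected range of 130 nM to 1200 nM.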

Compound 4, half-maximal inhibitory concentration: 175 nM
For compound 4 the middle estimate is 2.3-fold (0.36 log units) above the measured one, and the stated range covers the measured number.
By their numbers in this assay, from the lowest: compounds 1, 4 and 2 (each within the scatter of the next); then compound 3.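

In this assay, bromo in place of hydrogen on this saturated chain carbon bound to a carbonyl carbon gives a 3.2-fold lower number from compound 3 to compound 4 (0.50 log units; beyond the scatter), so this carbon tolerates substitution and the number responds to it. Against the free amine, (bromomethyl)carbonyl gives a 1.2-fold lower number from compound 2 to compound 4 (0.08 log units; within the scatter), so the rise seen with acetyl does not hold for every acyl group on this nitrogen. Nothing shown gives a reason for this difference. The compounds shown leave open whether chloro or methoxy on this carbon would give the same lower number as bromo. They also leave open whether a longer chain carrying the bromo would keep it.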